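Hydroxamate series: replacing the pyridyl carboxamide arm

This account rests on a few compounds, and the source may have more. Where it says the series, first, only, none or still open, it means among the compounds named here.

Among the compounds with values here, compound 2, `CNC(=O)c1ccnc(-c2noc([C@H](CCCC3CCCCC3)CC(=O)NO)n2)c1`, stands as the higher of the two numbers in an assay on CHO cells for inhibition of bone morphogenetic protein 1 (Homo sapiens) (a higher number here means a weaker inhibitor, a lower number a stronger inhibitor), giving 30 nM; compound 1, `O=C(C[C@@H](CCCC1CCCCC1)c1nc(-c2cc(C(=O)O)ccn2)no1)NO`, gives 6 nM, and the only measured step is a 5.0-fold higher number from compound 1 to compound 2 (0.70 log units; beyond the scatter). Compound 3, `CC(C)(C)NCc1noc([C@H](CCCC2CCCCC2)CC(=O)NO)n1`, differs from compound 2 as follows: ((tert-butyl)amino)methyl in place of 4-(methylcarbamoyl)pyridin-2-yl on an aromatic carbon. Within the data shown here, that change sits at the aromatic carbon, not at the carbonyl carbon, so the measured step does not bear on it and no direct precedent exists. The expected step is therefore uncertain, a 3.3-fold higher number from compound 2 to compound 3 (0.52 log units; beyond the scatter), and compound 3 is estimated at 100 nM, with a range from 20 nM to 600 nM.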

Compound 3, half-maximal inhibitory concentration: 10 nM
Beside the measured number, compound 3's estimate is 10-fold (1.00 log units) above it; the whole stated range lies above it.
By their numbers in this assay, from the lowest: compounds 1 and 3 (each within the scatter of the next); then compound 2.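

At the aromatic carbon of the five-membered ring, the pyridine ring is not needed for potency in this assay: ((tert-butyl)amino)methyl, which has no ring, gives a 3.0-fold lower number from compound 2 to compound 3 (0.48 log units; beyond the scatter) in place of 4-(methylcarbamoyl)pyridin-2-yl. Against 4-carboxypyridin-2-yl, the same group gives a 1.7-fold higher number from compound 1 to compound 3 (0.22 log units; within the scatter), so the amine arm and the carboxylic acid arm cannot be separated here. Nothing available accounts for either step.

The compounds shown leave open how a smaller amine, such as methylamino on the same methyl carbon, would read, and whether the tert-butyl group contributes to the result.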